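This account rests on a few compounds, and the source may have more. Where it says the series, first, only, none or still open, it means among the compounds named here.

Four compounds share one core and differ only in the aryl group attached to it and in one substituent on that group. Compound 1 `COc1ccc(-c2cc(N3CCC(CNS(N)(=O)=O)CC3)ncn2)cc1` carries a 4-methoxyphenyl, compound 2 `NS(=O)(=O)NCC1CCN(c2cc(-c3ccc(Cl)cc3)ncn2)CC1` a 4-chlorophenyl, compound 3 `COc1ccccc1-c1cc(N2CCC(CNS(N)(=O)=O)CC2)ncn1` a 2-methoxyphenyl, and compound 4 `NS(=O)(=O)NCC1CCN(c2cc(-c3ccccc3Cl)ncn2)CC1`, still to be measured, a 2-chlorophenyl.

In a functional assay on MCF7 cells (Homo sapiens) for antiproliferative activity, read by sulforhodamine B assay, with a stated time of 48 h (on this read-out higher numbers stand for weaker inhibition of growth and lower numbers for stronger inhibition of growth), compound 1 gives 35300 nM. In this assay compound 2 gives 25500 nM. In this assay compound 3 gives 10100 nM, the lowest number of the three. The change from compound 1 to compound 2 is chloro in place of methoxy on an aromatic carbon, and it produced a 1.4-fold lower number from compound 1 to compound 2 (0.14 log units; within the scatter). The cores of compound 1 and compound 3 differ as follows: 2-methoxyphenyl in place of 4-methoxyphenyl on an aromatic carbon; that change gave a 3.5-fold lower number from compound 1 to compound 3 (0.54 log units; beyond the scatter), and between compound 2 and compound 3 the step was a 2.5-fold lower number from compound 2 to compound 3 (0.40 log units; beyond the scatter).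

Compound 4 relates to compound 3 as compound 2 relates to compound 1: chloro in place of methoxy on an aromatic carbon. The surroundings are not identical, since in the earlier pair the exchange sits para to a large group while here it sits ortho to a large group, so this counts as the same kind of change rather than the same change. Because the earlier exchange produced a 1.4-fold lower number from compound 1 to compound 2 (0.14 log units; within the scatter), a similarly small step is expected here, a 1.3-fold lower number from compound 3 to compound 4 (0.10 log units; within the scatter), with the wider spread reflecting the different position. Compound 4 is therefore estimated at 8000 nM, between 3500 nM and 18000 nM.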

Compound 4, concentration for 50% growth inhibition: 62400 nM
Beside the measured number, compound 4's estimate is 7.8-fold (0.89 log units) below it; measured number above the stated range.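

With a 6.2-fold higher number from compound 3 to compound 4 (0.79 log units; beyond the scatter), the exchange of methoxy for chloro did not carry over from the pair holding the 4-methoxyphenyl to the pair holding the 2-methoxyphenyl: the same change on two cores in this assay, a 1.4-fold lower number (0.14 log units; within the scatter) from compound 1 to compound 2 and a 6.2-fold higher number (0.79 log units; beyond the scatter) from compound 3 to compound 4, 8.6-fold (0.93 log units) apart, beyond the scatter of two such steps. The same split appears when each group is moved, with a 3.5-fold lower number from compound 1 to compound 3 (0.54 log units; beyond the scatter) for the methoxy compounds but a 2.4-fold higher number from compound 2 to compound 4 (0.39 log units; beyond the scatter) for the chloro compounds, so in this assay the effect of each change depends on the other feature of the aryl group. Compound 4 nonetheless ends with a 1.8-fold higher number from compound 1 to compound 4 (0.25 log units; within the scatter), and while these four compounds show that a small step on one pair did not foretell the step on the other, they do not show why the two steps part, nor do they give a rule for any other core.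

The compounds shown leave open whether this dependence is particular to methoxy and chloro, or whether a fluoro, a methyl or a nitrile at the same place on the aryl group would show it too. They also leave open whether the split would persist if an amine or a carboxylic acid took the place of the side chain on the shared core.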